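The source may report more compounds than this note shows. Statements on the series, on what has been measured and on what is new or still open speak of the compounds shown alone.

Measured in a functional assay on BGC-823 cells (Homo sapiens) for inhibition, read by MTT assay, with a stated time of 72 h; a higher number here means a weaker inhibitor, a lower number a stronger inhibitor:
- Compound 1 `Cc1cc(N2CC[C@@H](C)[C@@H](N(C)c3ncnc4[nH]ccc34)C2)n2nc(SCc3nc4ccccc4[nH]3)nc2n1`: > 100000 nM
- Compound 2 `CCc1cc(N2CC[C@@H](C)[C@@H](N(C)c3ncnc4[nH]ccc34)C2)n2ncnc2n1`: 82200 nM

The entry for compound 1 is a limit of the assay and not a number. It stands at the limit of > 100000 nM in this assay, at which 1 of the 2 values shown sits.

Compound 3 `Cc1ccc(CSc2nc3nc(C)cc(N4CC[C@@H](C)[C@@H](N(C)c5ncnc6[nH]ccc56)C4)n3n2)cc1` differs from compound 1 at one place: 4-methylphenyl in place of 1H-benzimidazol-2-yl on a saturated chain carbon bound to a sulfur.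

Among the measured compounds shown here, no measured pair shows this change, so only a small step toward stronger inhibition, or none beyond the scatter, is expected in this assay. Compound 2 gives 82200 nM, which also offers no sign of strong inhibition in this series. The expected step is an at least 1.6-fold lower number from compound 1 to compound 3 (0.22 log units; that floor lies within the scatter).

For compound 3 the estimated value is 60000 nM, with an expected range of 15000 nM to 150000 nM.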

Compound 3, half-maximal inhibitory concentration: 69500 nM
Compound 3: middle estimate off by 1.2-fold (0.06 log units), on the low side, and the stated range covers the measured number.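

In this assay, 4-methylphenyl in place of 1H-benzimidazol-2-yl on a saturated chain carbon bound to a sulfur gives an at least 1.4-fold lower number from compound 1 to compound 3 (0.15 log units; that floor lies within the scatter). The entry for compound 1 is a limit of the assay, so the step has only a floor and its true size stays unknown: the limit of > 100000 nM in this assay, at which 1 of the 3 values shown sits.

Even so, compound 3 yields a real number, 69500 nM, with a carbon-only ring group at this place, and that number still offers no sign of strong inhibition. Going by these compounds, whether an amine or a carboxylic acid at this place would give a much lower number stays open. So does the effect of a longer chain between the sulfur and the ring.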